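The source may hold more compounds than are shown below. What is called first, only, known or untested is meant among the compounds shown, and "the series" means these compounds.

Compound 1 `CCOC(=O)c1c(-c2ccc(C(C)(C)C)cc2)[nH]c2cccc(OC)c2c1=O` and compound 2 `CCOC(=O)c1c(-c2ccccc2)[nH]c2cccc(OC)c2c1=O` share one core. In a physicochemical assay for solubility, in phosphate buffer, at pH 7.4 (a higher number here means a more soluble compound, a lower number a less soluble compound), compound 1 gives 1000 nM. For compound 2 the result in this assay is only a limit of the assay, > 100000 nM, not a number. Among the measured compounds shown here, the single measured step, an at least 100-fold higher number from compound 1 to compound 2 (2.00 log units; beyond the scatter), is the only guide, and it is marked by the limit of > 100000 nM in this assay, at which 1 of the 2 values shown sits. Compound 3 `CCOC(=O)c1c(-c2ccc(Cl)c(Cl)c2)[nH]c2cccc(OC)c2c1=O` differs from compound 2 by 3,4-dichlorophenyl in place of phenyl on an aromatic carbon, so chlorines are placed on the same ring from which the measured step took away a tert-butyl. Because that step, an at least 100-fold higher number from compound 1 to compound 2 (2.00 log units; beyond the scatter), raised the number greatly when a substituent was removed, the reverse direction, adding substituents, is expected to lower the number, by roughly an at least 20-fold lower number from compound 2 to compound 3 (1.30 log units; beyond the scatter). Compound 3 is therefore estimated at 5000 nM, with a likely range from 1000 nM to 40000 nM, and a fair chance that only a limit is reported.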

Compound 3, solubility: 39000 nM
Compound 3: middle estimate off by 7.8-fold (0.89 log units), on the low side; the measured number falls inside the stated range.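

Among the compounds shown here, replacing phenyl with 3,4-dichlorophenyl at this position shows that tert-butyl is not the only change to this ring that lowers the number in this assay: an at least 2.5-fold lower number from compound 2 to compound 3 (0.40 log units; beyond the scatter). The kind of substituent also matters, as compound 3 gives 39000 nM, while compound 1, with its tert-butyl group on the same ring, gives 1000 nM. The true size of the new step stays unknown because compound 2 has only a limit of the assay, not a number: the limit of > 100000 nM in this assay, at which 1 of the 3 values shown sits.

On these data alone, whether one chlorine alone would lower the number, and which of the two chlorines counts for more, stays open. So does the effect on this number of an amine or a carboxylic acid on the same ring.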